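This account rests on a few compounds, and the source may have more. Where it says the series, first, only, none or still open, it means among the compounds named here.

Measured in a physicochemical assay for solubility, read by nephelometry, in phosphate buffer, at pH 7.4; a higher number here means a more soluble compound, a lower number a less soluble compound:
- compound 1 `COc1cc(/C=C/C(=O)NCCn2c(C(F)(F)F)cc3ccccc32)cc(OC)c1OCCO`: 35000 nM
- compound 2 `Cc1cc2ccccc2n1CCNC(=O)/C=C/c1ccc(OCCCN(C)C)cc1`: 306000 nM
- compound 3 `Cc1cc(/C=C/C(=O)NCCn2c(C)cc3ccccc32)cc(C)c1F`: < 25000 nM

For the measured compounds named here, only two of these readings are numbers. In this assay compound 2 stands highest of the two, at 306000 nM. Compound 1 lies lower at 35000 nM, and that gap is beyond the scatter. For compound 3 the entry < 25000 nM is a limit of the assay and not a number.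

The next compound is compound 4 `Cc1cc2ccccc2n1CCNC(=O)/C=C/c1ccc(OCCO)cc1`, which differs from compound 2 in one place: hydroxy in place of (dimethylamino)methyl on a saturated chain carbon, two bonds along the chain from an oxygen on an aromatic ring. Hydroxy stands in place of (dimethylamino)methyl on a saturated chain carbon, two bonds along the chain from an oxygen on an aromatic ring. Cut one bond further out, this is 3-(dimethylamino)propoxy to 2-hydroxyethoxy.

Going by the values given here, no measured pair shows this change, so the expectation rests on thin ground. Among the compounds with values here, compound 2 is the only measured compound with 3-(dimethylamino)propoxy, and its 306000 nM is the top number. Although it differs from compound 4 elsewhere too, compound 1 also carries 2-hydroxyethoxy and gives 35000 nM. A fall beyond the scatter is therefore expected, and the estimated size is a 5.6-fold lower number from compound 2 to compound 4 (0.75 log units; beyond the scatter). For compound 4 the expected value is 55000 nM, with an estimated range of 25000 nM to 130000 nM.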

Compound 4, solubility: 68000 nM
Compound 4: the middle estimate sits 1.2-fold (0.09 log units) below what was measured; low and high end bracket the measured number.
By their numbers in this assay, from the lowest: compounds 1 and 4 (each within the scatter of the next); then compound 2. At a limit, below all of these: compound 3.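

For the compounds shown here, this pair gives the first reading of the change with the rest of the molecule held fixed: in this assay, hydroxy in place of (dimethylamino)methyl on a saturated chain carbon, two bonds along the chain from an oxygen on an aromatic ring, gives a 4.5-fold lower number from compound 2 to compound 4 (0.65 log units; beyond the scatter). The earlier compounds shown here showed 3-(dimethylamino)propoxy and 2-hydroxyethoxy only on different cores and substitution patterns, so the drop is now tied to this position alone, and it is a real step, though a modest one. Nothing shown gives a measured reason for the size or direction of this step.

The swap changes the chain length and the end group in a single move, from 3-(dimethylamino)propoxy to 2-hydroxyethoxy, so this pair cannot divide the step between the two. A 3-hydroxypropoxy chain or a 2-(dimethylamino)ethoxy chain on the same core would separate them, and a carboxylic acid or a morpholine at the chain end would show whether the high reading of compound 2 is specific to the dimethylamino group.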